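A few compounds are considered here, and "the series" means these few. Any claim that something is new, unique, unknown or untested is made for them only; others in the source may bear on it.

Working notes on the series, which shares one core. Compound 1 `CCCc1cnc(N2CCC(C3Cc4c(F)c(C5=CCN(S(=O)(=O)CCC)CC5)cc(F)c4O3)CC2)nc1` gives 119% in a functional assay on HEK293 cells with Glucose-dependent insulinotropic receptor (Homo sapiens) as the target, read by cAMP accumulation, with a stated time of 60 min; a lower number here means a smaller maximal response, a higher number a larger maximal response. Compound 2 `CCCc1cnc(N2CCC(C3(C)Cc4cc(C5=CCN(S(=O)(=O)CCC)CC5)ccc4O3)CC2)nc1` gives 48% in this assay, and compound 3 `CCCc1cnc(N2CCC(C3(C)Cc4cc(C5=CCN(S(=O)(=O)CCCO)CC5)ccc4O3)CC2)nc1` gives 78% in this assay. Compound 3 therefore stands second highest of the three, nearest to compound 2 and furthest from compound 1, which differs from it in more than one place. Among the compounds with values here, the only measured single step, a number 30 percentage points higher from compound 2 to compound 3 (beyond the scatter), raised the maximal response by introducing the hydroxy. Compound 4 `CCCc1cnc(N2CCC(C3(C)Cc4cc(C5=CCN(S(=O)(=O)CCCCO)CC5)ccc4O3)CC2)nc1` carries the change (hydroxymethyl in place of hydroxy on a saturated chain carbon, three bonds along the chain from a sulfonyl sulfur). Within the data shown here, no measured step bears on lengthening the hydroxy-bearing chain by one carbon while the hydroxy itself is kept, so a step within the scatter in this assay is expected, in either direction. For compound 4 an estimated 80% is given, with a range from 60% to 105%, meaning an expected step of a number 2 percentage points higher from compound 3 to compound 4 (within the scatter).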

Compound 4, largest response reached (Emax), in percent of the reference or control that the assay uses: 67%
The estimate for compound 4 lay 13 percentage points above the measured number; the range from low to high includes it.
By their numbers in this assay, from the lowest: compound 2; then compound 4; then compound 3; then compound 1.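

Lengthening the chain by one carbon with the hydroxy kept is not a silent change in this assay: 3-hydroxypropyl to 4-hydroxybutyl gives a number 11 percentage points lower from compound 3 to compound 4 (beyond the scatter), so the maximal response at this position depends on where the hydroxy sits as well as on its presence. The gain over the plain propyl chain persists, at a number 19 percentage points higher from compound 2 to compound 4 (beyond the scatter), but it is smaller than a number 30 percentage points higher from compound 2 to compound 3 (beyond the scatter), the step with the shorter chain. From the compounds shown here alone, whether a longer chain, or an amine or a carboxylic acid in place of the hydroxy, would keep or raise the maximal response remains open. Nothing available accounts for the difference between the two hydroxy chains.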